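A few compounds are considered here, and "the series" means these few. Any claim that something is new, unique, unknown or untested is made for them only; others in the source may bear on it.

Measured compounds and their values:
- Compound 1, `Cc1cc(=O)n(-c2ccccc2C(F)(F)F)nc1C(=O)Nc1ccc(Oc2ncnc3ccsc23)cc1`, in a functional assay on A549 cells (Homo sapiens) for cytotoxicity, read by MTT assay, with a stated time of 72 h; on this read-out lower numbers stand for stronger inhibition and higher numbers for weaker inhibition: 8850 nM
- Compound 2, `Cc1ccc(-n2nc(C(=O)Nc3ccc(Oc4ncnc5ccsc45)cc3)c(C)cc2=O)cc1`: 11500 nM
- Compound 3, `Cc1cc(=O)n(-c2ccc(F)cc2)nc1C(=O)Nc1ccc(Oc2ncnc3ccsc23)cc1`: 2360 nM

Of these three numbers, compound 3 holds the lowest. Its separation from the other two is beyond the scatter in both directions: a 3.8-fold lower number from compound 1 to compound 3 (0.57 log units; beyond the scatter) and a 4.9-fold lower number from compound 2 to compound 3 (0.69 log units; beyond the scatter). Between the other two, a 1.3-fold higher number from compound 1 to compound 2 (0.11 log units; within the scatter) stays within the scatter, so nothing can be said of an order between compound 1 and compound 2.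

Compound 4, `Cc1cc(=O)n(-c2ccc(F)cc2)nc1C(=O)Nc1ccc(Oc2ncnc3ccsc23)c(F)c1`, is compound 3 with one alteration: fluoro in place of hydrogen on an aromatic carbon. Going by the values given here, none of the measured steps touches this part of the shared core. Among the compounds with values here, the only step in which a fluoro appears, from compound 2 to compound 3, exchanges it for a methyl on a different ring, and the other two steps swap whole aryl groups on the aromatic nitrogen. The data therefore offer no direct guide to the size or direction of this change in this assay, and the working expectation is a step of no more than the usual scatter. On that basis compound 4 is expected to give about 2400 nM, with a range from 900 nM to 6500 nM. That estimate corresponds to a 1.0-fold higher number from compound 3 to compound 4 (0.01 log units; within the scatter), an expected step within the scatter, with a wide range reflecting the absence of any comparable measured step.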

Compound 4, half-maximal inhibitory concentration: 580 nM
Estimate against measurement, compound 4: 4.1-fold (0.62 log units) above, and the stated range ends above it.
By their numbers in this assay, from the lowest: compound 4; then compound 3; then compounds 1 and 2 (each within the scatter of the next).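

In this assay, going by these compounds alone, the single added fluoro gives a 4.1-fold lower number from compound 3 to compound 4 (0.61 log units; beyond the scatter) on a part of the shared core that no earlier step had touched. This position, on an aromatic carbon of a six-membered aromatic ring of carbon only, ortho to a large group and meta to a large group, therefore responds beyond the scatter to a change of one heavy atom, and the step is of a size earlier seen here only with changes on the aryl group on the aromatic nitrogen. Nothing available here accounts for this response to the fluoro.

The compounds shown leave open whether the response is particular to fluoro or extends to other replacements of hydrogen at this carbon, a question that a chloro, a methoxy or an amine in the same place would address. They also leave open whether the same fluoro gives a step of similar size alongside the 2-(trifluoromethyl)phenyl of compound 1 or the 4-methylphenyl of compound 2, in place of the 4-fluorophenyl of compound 3.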